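Adding trifluoromethyl to the phenyl of compound 3

The source may hold more compounds than are shown below. What is called first, only, known or untested is meant among the compounds shown, and "the series" means these compounds.

In a functional assay on U-937 cells (Homo sapiens) for antiproliferative activity, read by MTT assay, with a stated time of 72 h (on this read-out lower numbers stand for stronger inhibition and higher numbers for weaker inhibition), compound 3 `Nc1ccccc1NC(=O)CCCCCCc1nc(-c2ccccc2)no1` gives 730 nM, level with compound 1 `O=C(CCCCCCc1nc(-c2ccccc2Cl)no1)NO` at 750 nM. Compound 2 `O=C(CCCCCCc1nc(-c2cccs2)no1)NO` gives the lowest number of the three, at 320 nM. Compound 3 therefore sits at the upper end of this small set, within the scatter of compound 1.

The next analogue is compound 4 `Nc1ccccc1NC(=O)CCCCCCc1nc(-c2ccc(C(F)(F)F)cc2)no1`, which differs from compound 3 by trifluoromethyl in place of hydrogen on an aromatic carbon, para to a large group, taking phenyl to 4-(trifluoromethyl)phenyl: trifluoromethyl in place of hydrogen on an aromatic carbon.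

Among the compounds with values here, only one measured step bears on this change, and only indirectly. Thiophen-2-yl in place of 2-chlorophenyl on an aromatic carbon gives a 2.3-fold lower number from compound 1 to compound 2 (0.37 log units; beyond the scatter), a modest step just beyond the scatter. Within the data shown here, that pair differs from compound 3 at the other end of the chain, and neither of its members tests trifluoromethyl, so the data give no direct precedent. Among the measured compounds shown here, it suggests only that aromatic changes have so far moved the number modestly.

The expected change is small and slightly upward, a 1.1-fold higher number from compound 3 to compound 4 (0.04 log units; within the scatter), and is not expected to lie beyond the scatter. The estimate for compound 4 is 800 nM, with an expected range of 300 nM to 2000 nM.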

Compound 4, half-maximal inhibitory concentration: 5280 nM
The estimate for compound 4 lay 6.6-fold (0.82 log units) below the measured number; measured number above the stated range.
By their numbers in this assay, from the lowest: compound 2; then compounds 3 and 1 (each within the scatter of the next); then compound 4.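

Trifluoromethyl in place of hydrogen on an aromatic carbon, para to a large group, gives in this assay a 7.2-fold higher number from compound 3 to compound 4 (0.86 log units; beyond the scatter) and so moves the number towards weaker inhibition. Within the data shown here, this is the first step that changes a single place on the phenyl of compound 3, whereas the only earlier step, between compound 1 and compound 2, swaps one whole aromatic group for another and carries a different group at the far end of the chain. The phenyl of compound 3 is therefore not a neutral place for substitution in this read-out, at least for trifluoromethyl, and nothing measured here accounts for the rise, which stands as an observation on this one pair.

As far as these compounds go, whether the rise belongs to trifluoromethyl itself or to any group at this place remains open, and a fluorine, a methyl or a methoxy on the same aromatic carbon would separate the two. Also open, from the compounds shown here alone, is whether the same change carries over to the hydroxamic acid end shared by compound 1 and compound 2, or holds only with the aminophenyl amide of compound 3 and compound 4.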